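Series notes: 3,4-dichlorophenyl replacing 3,4-difluorophenyl

The source may hold more compounds than are shown below. What is called first, only, known or untested is meant among the compounds shown, and "the series" means these compounds.

Measured so far in an assay for inhibition of RAC-alpha serine/threonine-protein kinase (Homo sapiens), read by HTRF, with a stated time of 1 h; a lower number here means a stronger inhibitor, a higher number a weaker inhibitor:
Compound 1 `CNC(=O)C[C@@H]1C[C@@H](c2ccc(Cl)c(Cl)c2)[C@H](NC(=O)c2cc(-c3c(Cl)cnn3C)c(Cl)o2)CN1`: 2.64 nM
Compound 2 `Cn1ncc(Cl)c1-c1cc(C(=O)N[C@@H]2CN[C@H](CCNS(C)(=O)=O)C[C@H]2c2ccc(F)c(F)c2)oc1Cl`: 3.29 nM
Compound 3 `Cn1ncc(Cl)c1-c1cc(C(=O)N[C@@H]2CN[C@H](CC(O)CO)C[C@H]2c2ccc(F)c(F)c2)oc1Cl`: 3.31 nM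

Compound 3 holds the highest of the three numbers, yet its nearest neighbour compound 2 and its furthest neighbour compound 1 both lie within the scatter of it. Going by the values given here, the one step among measured pairs, a 1.0-fold higher number from compound 2 to compound 3 (0.00 log units; within the scatter), is flat.

Compound 4 `Cn1ncc(Cl)c1-c1cc(C(=O)N[C@@H]2CN[C@H](CC(O)CO)C[C@H]2c2ccc(Cl)c(Cl)c2)oc1Cl` differs from compound 3 by 3,4-dichlorophenyl in place of 3,4-difluorophenyl on a saturated ring carbon. Among the compounds with values here, no measured step covers this swap directly. Compound 1, which already carries the 3,4-dichlorophenyl group beside a different chain, gives 2.64 nM, indistinguishable from compounds 2 and 3. Accordingly no step beyond the scatter is expected, a 1.2-fold lower number from compound 3 to compound 4 (0.07 log units; within the scatter). Compound 4 is estimated at 2.8 nM, with a range of 1.2 nM to 6.5 nM.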

Compound 4, half-maximal inhibitory concentration: 3.79 nM
For compound 4 the middle estimate is 1.4-fold (0.13 log units) below the measured one, and the stated range covers the measured number.
By their numbers in this assay, from the lowest: compounds 1, 2, 3 and 4 (each within the scatter of the next).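

In this assay the swap to 3,4-dichlorophenyl from 3,4-difluorophenyl on the saturated ring carbon now has a direct reading with the 2,3-dihydroxypropyl group held fixed, and it stays within the scatter (a 1.1-fold higher number from compound 3 to compound 4 (0.06 log units; within the scatter)). With 3,4-dichlorophenyl held fixed, the chain change also stays within the scatter (a 1.4-fold higher number from compound 1 to compound 4 (0.16 log units; within the scatter)), so the flat chain step seen among the 3,4-difluorophenyl compounds recurs with the dichloro group. Nothing available bears on the reason for these flat steps.

Still open, on these data alone, is whether an unsubstituted phenyl at this position, or an amine or carboxylic acid on the chain, would give a step beyond the scatter.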